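Crotonate Ester Replaces Thiophene Ether on the Shared Core

The compounds below may be only part of what the source reports. "The series", "measured", "known", "first", "only" and "open" are said of these compounds alone.

Measured so far:
compound 1 `CS(=O)(=O)OC1=CC(=O)c2ccccc2C1=O` — 7180 nM
compound 2 `CC(=O)OC1=CC(=O)c2ccccc2C1=O` — 38800 nM
compound 3 `O=C1C=C(Oc2cccs2)C(=O)c2ccccc21` — 41500 nM

In a functional assay on KB cells (Homo sapiens) for cytotoxicity (on this read-out higher numbers stand for weaker inhibition and lower numbers for stronger inhibition), compound 3 gives the highest number of the three. One of its steps is within the scatter, a 1.1-fold higher number from compound 2 to compound 3 (0.03 log units; within the scatter), while the other is far larger, a 5.8-fold higher number from compound 1 to compound 3 (0.76 log units; beyond the scatter). Compound 4 `C/C=C/C(=O)OC1=CC(=O)c2ccccc2C1=O` differs from compound 3 by (prop-1-en-1-yl)carbonyl in place of thiophen-2-yl on an oxygen on an unsaturated carbon. Among the measured compounds shown here, no measured step matches this exactly. The nearest guide is a 1.1-fold higher number from compound 2 to compound 3 (0.03 log units; within the scatter): acetyl and thiophen-2-yl on that oxygen gave numbers within the scatter of each other, and the entering (prop-1-en-1-yl)carbonyl is, like acetyl, a carbonyl group on the same oxygen. Compound 4 is therefore expected to stay close to compound 3, with a 1.3-fold lower number from compound 3 to compound 4 (0.11 log units; within the scatter) inside the scatter. The estimated value for compound 4 is 32000 nM, with a range from 11000 nM to 95000 nM.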

Compound 4, half-maximal inhibitory concentration: 64200 nM
Estimate against measurement, compound 4: 2.0-fold (0.30 log units) below, and the stated range covers the measured number.
By their numbers in this assay, from the lowest: compound 1; then compounds 2, 3 and 4 (each within the scatter of the next).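

In this assay, the new ester on this oxygen cannot be told apart from the thiophene ether (a 1.5-fold higher number from compound 3 to compound 4 (0.19 log units; within the scatter)), and replacing methyl with prop-1-en-1-yl on the carbonyl carbon also stays within the scatter (a 1.7-fold higher number from compound 2 to compound 4 (0.22 log units; within the scatter)). Compound 1 remains apart from this new ester (an 8.9-fold higher number from compound 1 to compound 4 (0.95 log units; beyond the scatter)), so a larger carbonyl group on this oxygen does not close the gap to methylsulfonyl. No measured evidence explains these numbers. Still open, as far as these compounds go, is whether phenylsulfonyl or a longer chain on the sulfur would keep the lower number of compound 1.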